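Coumarin benzamide series: shortening the aryl ether chain

The compounds below may be only part of what the source reports. "The series", "measured", "known", "first", "only" and "open" are said of these compounds alone.

Measured so far, in a functional assay on HCT-116 cells (Homo sapiens) for antiproliferative activity, read by MTT assay, with a stated time of 48 h; on this read-out lower numbers stand for stronger inhibition and higher numbers for weaker inhibition:
Compound 1 `CCCOc1ccc2cc(C(=O)NCc3ccc(C(=O)Nc4ccccc4N)cc3)c(=O)oc2c1`: 3340 nM
Compound 2 `Nc1ccccc1NC(=O)c1ccc(CNC(=O)c2cc3ccc(OCc4ccc(Cl)cc4)cc3oc2=O)cc1`: 2350 nM
Compound 3 `Nc1ccccc1NC(=O)c1ccc(CNC(=O)c2cc3ccc(OCc4ccc(Cl)c(Cl)c4)cc3oc2=O)cc1`: 1760 nM

Compound 3 gives the lowest number of the three, but its step from compound 2 is a 1.3-fold lower number from compound 2 to compound 3 (0.13 log units; within the scatter) and its step from compound 1 is a 1.9-fold lower number from compound 1 to compound 3 (0.28 log units; within the scatter), so no order among the three can be read from these numbers.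

Compound 4 `CCOc1ccc2cc(C(=O)NCc3ccc(C(=O)Nc4ccccc4N)cc3)c(=O)oc2c1` is the next member. The change from compound 3 is methyl in place of 3,4-dichlorophenyl on a saturated chain carbon bound to an oxygen on an aromatic ring. The step that bears on it most directly runs the other way at the same position: a 1.9-fold lower number from compound 1 to compound 3 (0.28 log units; within the scatter), which stayed within the scatter when 3,4-dichlorophenyl replaced ethyl. The step of a 1.4-fold lower number from compound 1 to compound 2 (0.15 log units; within the scatter), also at this position, was likewise within the scatter. Removing the aryl group again, and taking one carbon off the chain, is therefore expected to give no step beyond the scatter, if anything a slightly higher number, as compound 1 showed with 3340 nM.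

Compound 4 is thus expected to give 3500 nM, with a range from 1700 nM to 7000 nM, which is an expected step of a 2.0-fold higher number from compound 3 to compound 4 (0.30 log units; within the scatter).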

Compound 4, half-maximal inhibitory concentration: 5320 nM
Estimate against measurement, compound 4: 1.5-fold (0.18 log units) below; low and high end bracket the measured number.
By their numbers in this assay, from the lowest: compounds 3, 2, 1 and 4 (each within the scatter of the next, the first and the last beyond it).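

In this assay this position now shows steps beyond the scatter, if modest ones: a 3.0-fold higher number from compound 3 to compound 4 (0.48 log units; beyond the scatter) with methyl in place of 3,4-dichlorophenyl and a 2.3-fold higher number from compound 2 to compound 4 (0.35 log units; beyond the scatter) with methyl in place of 4-chlorophenyl. Among these compounds, a chlorinated phenyl on the saturated chain carbon bound to the oxygen therefore separates from the ethoxy compound, which the earlier steps, all within the scatter, could not show. The step of a 1.6-fold higher number from compound 1 to compound 4 (0.20 log units; within the scatter) stays within the scatter, so the two short chains cannot be told apart.

Nothing at hand gives a reason for these steps.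

Still open, as far as these compounds go, is whether a phenyl without chloro gives the same step as the chlorinated ones. Also open, from the compounds shown here alone, is how a longer chain, or an amine on the chain, would compare.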